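The source may report more compounds than this note shows. Statements on the series, on what has been measured and on what is new or still open speak of the compounds shown alone.

Measured compounds in a functional assay on HL-60 cells (Homo sapiens); a lower number here means a stronger inhibitor of growth, a higher number a weaker inhibitor of growth:
compound 1 `COC(=O)/C=C/C[C@H]1OCCC[C@@H]1O[Si](C)(C)C(C)(C)C` gives 22000 nM
compound 2 `CC(C)(C)[Si](C)(C)O[C@H]1CCCO[C@@H]1C/C=C/CO` gives 27000 nM
compound 3 `CC(C)(C)[Si](C)(C)O[C@H]1CCCO[C@@H]1/C=C/CO` gives 31000 nM

Compound 1 has the lowest of the three numbers, but the other two sit within the scatter of it: a 1.2-fold higher number from compound 1 to compound 2 (0.09 log units; within the scatter) and a 1.4-fold higher number from compound 1 to compound 3 (0.15 log units; within the scatter). Compound 2 and compound 3 likewise sit within the scatter of each other, a 1.1-fold higher number from compound 2 to compound 3 (0.06 log units; within the scatter). Across the whole series, the exchange of the methoxycarbonyl-bearing chain for a hydroxyl-bearing chain, and the shortening of that chain, have given no step in this assay that rises above the scatter.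

Compound 4 `CC(C)(C)[Si](C)(C)O[C@H]1CCCO[C@@H]1/C=C\CO` is the next member. Relative to compound 1 the change is 3-hydroxyprop-1-en-1-yl in place of 3-(methoxycarbonyl)prop-2-en-1-yl on a saturated ring carbon. In words this is the same exchange as from compound 1 to compound 3; compound 4 differs from compound 3 only in the geometry of the double bond in the entering chain. The step that bears directly on it, a 1.4-fold higher number from compound 1 to compound 3 (0.15 log units; within the scatter), was within the scatter, as were the two others. No step beyond the scatter is therefore expected in this assay, and the estimated step is a 1.3-fold higher number from compound 1 to compound 4 (0.10 log units; within the scatter). Compound 4 is expected to give about 28000 nM, with a range from 14000 nM to 56000 nM.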

Compound 4, concentration for 50% growth inhibition: 26000 nM
For compound 4 the middle estimate is 1.1-fold (0.03 log units) above the measured one, within the range that was stated.
By their numbers in this assay, from the lowest: compounds 1, 4, 2 and 3 (each within the scatter of the next).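

Among the compounds shown here, the new point at this saturated ring carbon is the geometry of the double bond in the 3-hydroxyprop-1-en-1-yl chain, which the earlier compounds showed in only one form. In this assay, the change from E to Z gives a step within the scatter (a 1.2-fold lower number from compound 3 to compound 4 (0.08 log units; within the scatter)), so this geometry has not separated the two compounds, and that step can be read as a geometry comparison alone: the fact that compounds 3 and 4 differ only in the configuration as drawn

For the compounds shown here, the Z chain also fits the flat picture set by the earlier compounds, with no step beyond the scatter against the 3-(methoxycarbonyl)prop-2-en-1-yl chain (a 1.2-fold higher number from compound 1 to compound 4 (0.07 log units; within the scatter)) or the 4-hydroxybut-2-en-1-yl chain (a 1.0-fold lower number from compound 2 to compound 4 (0.02 log units; within the scatter)).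

Open, as far as these compounds go, is whether a chain ending in an amine or a carboxylic acid, or a longer chain, on this saturated ring carbon would give a step beyond the scatter. Equally open is whether the Z and E forms would also stay within the scatter in the 4-hydroxybut-2-en-1-yl and 3-(methoxycarbonyl)prop-2-en-1-yl chains, each shown here with one double-bond geometry only.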